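Compound 3 to compound 4: losing the alkoxy group

The source may report more compounds than this note shows. Statements on the series, on what has been measured and on what is new or still open speak of the compounds shown alone.

In an ADME assay on a cell-free system (plasma, Homo sapiens) for metabolic stability, read by LC-MS (on this read-out lower numbers stand for a shorter-lived compound and higher numbers for a longer-lived compound), compound 1 `NCc1ccc(C(=O)Nc2ccncc2F)cc1-c1cccc(C(=O)OCC2CCCO2)c1` gives < 0.0834 h, which is a limit of the assay. Compound 2 `COC(=O)c1cccc(NC(=O)c2cccc(-c3cc(C(=O)Nc4ccncc4F)ccc3CN)c2)c1F` gives < 0.0834 h, also a limit. Compound 3 `CC(C)OC(=O)c1cccc(NC(=O)c2cccc(-c3cc(C(=O)Nc4ccncc4F)ccc3CN)c2)c1`, at 0.567 h, is the only one of the three with an actual number. Compound 4 `NCc1ccc(C(=O)Nc2ccncc2F)cc1-c1cccc(C(=O)Nc2cccc(C(=O)O)c2F)c1` carries 3-carboxy-2-fluorophenyl in place of 3-(isopropoxycarbonyl)phenyl on an amide-type nitrogen. Two measured steps are nearby. The first, a step that the two limits leave unreadable from compound 1 to compound 2, gives no usable size. For the measured compounds named here, the second, an at least 6.7-fold higher number from compound 2 to compound 3 (0.83 log units; beyond the scatter), changes the same place on the amide-type nitrogen and is the only readable step, but neither step brings in a carboxy group. Compounds 1, 2 and 3 all keep an alkoxy group on the carbonyl carbon, whereas compound 4 has none, so the measured steps can only loosely guide the expectation. A rise is expected in this assay, estimated as a 7.1-fold higher number from compound 3 to compound 4 (0.85 log units; beyond the scatter). For compound 4 the estimate is 4 h, with an expected range of 0.8 h to 24 h.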

Compound 4, half-life: > 2 h
Compound 4: a limit, no number (the forecaster's own chance of this, stated with the estimate: 40%); the middle value is on the limit's open side.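

In this assay, a free carboxy group in place of an ester on the aryl group at the amide-type nitrogen gives an at least 3.5-fold higher number from compound 3 to compound 4 (0.54 log units; beyond the scatter), so the one ester with a measured number is also exceeded. Hydrogen in place of methyl on the ester oxygen gives an at least 23-fold higher number from compound 2 to compound 4 (1.37 log units; beyond the scatter), a change confined to that single group, and the comparison with the (oxolan-2-yl)methoxy ester gives an at least 23-fold higher number from compound 1 to compound 4 (1.37 log units; beyond the scatter). The value of compound 4 is a limit and not a number: the limit of > 2 h in this assay, at which 1 of the 4 values shown sits.

The step from compound 3 changes the ester and the fluorine together, and the compounds shown do not separate the two. Also open, as far as these compounds go, is how 3-carboxyphenyl without the fluorine, or a primary amide in place of the carboxy group, would read in this assay.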